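The compounds below may be only part of what the source reports. "The series", "measured", "known", "first", "only" and "open" are said of these compounds alone.

Measured in an ADME assay on the whole organism for metabolic stability, with Canis familiaris (Canis lupus familiaris) as the target, read by LC-MS, at a dose of 1 mg/kg by the intravenous route; on this read-out lower numbers stand for a shorter-lived compound and higher numbers for a longer-lived compound:
Compound 1 `Cc1cc(C(=O)N[C@H]2CCCCC/C=C\[C@@H]3C[C@@]3(C(=O)NS(=O)(=O)C3CC3)NC(=O)[C@@H]3C[C@@H](Oc4nc5ccccc5nc4C)CN3C2=O)no1`: 1.4 h
Compound 2 `Cc1cc(C(=O)N[C@H]2CCCCC/C=C\[C@@H]3C[C@@]3(C(=O)NS(=O)(=O)C3CC3)NC(=O)[C@@H]3C[C@@H](Oc4nc5cc(F)ccc5nc4C)CN3C2=O)no1`: 2 h

For the measured compounds named here, only two numbers exist so far, so compound 1 has a single point of comparison. In this assay, going by the values given here, compound 1 gives 1.4 h, and that number cannot be told apart from the one for compound 2, since the gap lies within the ordinary scatter of repeated measurements.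

The next compound is compound 3 `Cc1cc(C(=O)N[C@H]2CCCCC/C=C\[C@@H]3C[C@@]3(C(=O)NS(=O)(=O)C3CC3)NC(=O)[C@@H]3C[C@@H](Oc4nc5ccccc5nc4C(F)(F)F)CN3C2=O)no1`. It keeps the core of compound 1 and carries one change: trifluoromethyl in place of methyl on an aromatic carbon. Put simply, trifluoromethyl stands in place of methyl on an aromatic carbon, next to the ring nitrogen.

Among the compounds with values here, the only measured step is a 1.4-fold higher number from compound 1 to compound 2 (0.15 log units; within the scatter). It came with fluoro in place of hydrogen on an aromatic carbon, which is a different swap, so it offers only a loose guide. That small step gives no ground for expecting a clear shift in either direction in this assay, so none beyond the scatter is expected.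

The estimated step is a 1.2-fold higher number from compound 1 to compound 3 (0.08 log units; within the scatter). Compound 3 is expected at 1.7 h, with an estimated range of 0.8 h to 3.5 h.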

Compound 3, half-life: 1 h
Estimate against measurement, compound 3: 1.7-fold (0.23 log units) above; the range from low to high includes it.
By their numbers in this assay, from the lowest: compounds 3, 1 and 2 (each within the scatter of the next).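

In this assay, putting trifluoromethyl in place of methyl on this aromatic carbon, next to the ring nitrogen, gives a 1.4-fold lower number from compound 1 to compound 3 (0.15 log units; within the scatter), so this position tolerates the swap with no shift that can be told from the ordinary spread of repeat measurements. The earlier step, a 1.4-fold higher number from compound 1 to compound 2 (0.15 log units; within the scatter), came from fluoro in place of hydrogen on a different aromatic carbon, so it said nothing about the methyl group; the new result adds that replacing this methyl with trifluoromethyl also leaves the half-life within the scatter. No measurement shown explains why the half-life stays within the scatter with this change.

From the compounds shown here alone, it remains open whether a more different group at this position, such as an amine, a methoxy group or a longer chain like propyl, would move the number in this assay beyond the scatter. Going by these compounds, it is also open whether the fluoro of compound 2 and the trifluoromethyl of compound 3, carried together on one molecule, would do so when neither change alone has.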